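From Phenyl to 2,5-Dimethoxyphenyl on the Carbonyl Carbon

This account rests on a few compounds, and the source may have more. Where it says the series, first, only, none or still open, it means among the compounds named here.

Measured so far:
- compound 1, `O=C(/C=C/c1cn(-c2ccccc2)nc1-c1cccnc1)c1ccccn1`: 6400 nM
- compound 2, `O=C(/C=C/c1cn(-c2ccccc2)nc1-c1cccnc1)c1ccccc1`: 2300 nM

Both compounds were tested in a functional assay on Huh-7 cells (Homo sapiens) for inhibition, read by sulforhodamine B assay, with a stated time of 72 h; on this read-out lower numbers stand for stronger inhibition and higher numbers for weaker inhibition. Going by the values given here, compound 2 stands at the lower of the two numbers, and the single step recorded so far, a 2.8-fold lower number from compound 1 to compound 2 (0.44 log units; beyond the scatter), comes from putting phenyl in place of pyridin-2-yl on the carbonyl carbon. Among the compounds with values here, that is the only comparison available.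

Compound 3, `COc1ccc(OC)c(C(=O)/C=C/c2cn(-c3ccccc3)nc2-c2cccnc2)c1`, keeps everything in compound 2 except for one change: 2,5-dimethoxyphenyl in place of phenyl on a carbonyl carbon. The measured step touches the same carbonyl carbon, but it swaps one ring type for another rather than adding substituents to an existing ring, so it says little about what two methoxy groups will do. Within the data shown here, no measured pair shows the effect of methoxy groups at all. With nothing pointing in either direction, the expectation is a number close to that of compound 2, with no step beyond the scatter, though the range is wide. For compound 3 the estimate in this assay is 2000 nM, between 600 nM and 7000 nM, which would mean a step of a 1.2-fold lower number from compound 2 to compound 3 (0.06 log units; within the scatter).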

Compound 3, half-maximal inhibitory concentration: 1300 nM
Compound 3: the middle estimate sits 1.5-fold (0.19 log units) above what was measured; low and high end bracket the measured number.
By their numbers in this assay, from the lowest: compounds 3 and 2 (each within the scatter of the next); then compound 1.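

In this assay, the step of a 1.8-fold lower number from compound 2 to compound 3 (0.25 log units; within the scatter) shows that this carbonyl carbon can carry 2,5-dimethoxyphenyl as well as plain phenyl, with no difference that can be told apart from assay noise, even though the new group brings extra heavy atoms and two oxygen atoms. The comparison with the pyridine-bearing compound is clearer: the step of a 4.9-fold lower number from compound 1 to compound 3 (0.69 log units; beyond the scatter) lies beyond the scatter, so compound 3 joins compound 2 in standing apart from compound 1, and both compounds with a carbon-only ring at this place give lower numbers than the one with pyridin-2-yl. No measurement offered here accounts for these numbers, so the reason for this pattern remains unknown.

From the compounds shown here alone, the two methoxy groups arrive together, so what a single methoxy group would do, and whether either one matters more than the other, remains open. Also open, going by these compounds, is how this position would respond to an amine or a carboxylic acid on the ring, or to a cyclohexyl group in place of the aromatic ring.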